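The source may report more compounds than this note shows. Statements on the series, on what has been measured and on what is new or still open speak of the compounds shown alone.

Compound 1, with the structure `S=c1cc(-c2ccccc2)oc2ccccc12`, is the starting point. In an in vitro assay on BTI-TN-5B1-4 cells for inhibition of Amine oxidase [flavin-containing] B (Homo sapiens), tested at 100 uM (a lower number here means less inhibition, a higher number more inhibition at the concentration tested (going by the name of the read-out)), compound 1 gives 40%. Two measured neighbours share its core. Compound 2, `Cc1ccc2c(=S)cc(-c3ccccc3)oc2c1`, carries a methyl in place of hydrogen on an aromatic carbon and gives 40%. Compound 3, `Fc1ccc2c(=S)cc(-c3ccccc3)oc2c1`, carries a fluoro in place of hydrogen on an aromatic carbon and gives 40%. All three sit level at the digits shown: the step of no change at the digits printed from compound 1 to compound 2 (within the scatter), the step of no change at the digits printed from compound 1 to compound 3 (within the scatter), and the step of no change at the digits printed from compound 2 to compound 3 (within the scatter) all fall within the scatter, so compound 1 is neither above nor below its measured companions.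

The compound now in question is compound 4, with the structure `Fc1ccc(-c2cc(=S)c3ccccc3o2)cc1`. It differs from compound 1 by fluoro in place of hydrogen on an aromatic carbon. For the measured compounds named here, the step that bears most directly on it is the one from compound 1 to compound 3, where a fluoro entering for hydrogen on an aromatic carbon left the read-out unchanged; the methyl step from compound 1 to compound 2 likewise moved nothing. On this basis the step from compound 1 to compound 4 in this assay is expected to be no change at the digits printed from compound 1 to compound 4 (within the scatter), that is, no change beyond the scatter. Compound 4 is therefore estimated to give 40%, with a range from 28% to 52%.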

Compound 4, a percentage reported as inhibition, at one concentration (the size of the read-out at that concentration, not a potency): "not active" (no number reported)
For compound 4 the study gives words and no number, so the estimate cannot be set against anything.
By their numbers in this assay, from the lowest: compounds 1, 2 and 3 (each within the scatter of the next).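

For the compounds shown here, compound 4 is reported in this assay in words only, as "not active", so no step from compound 1, compound 2 or compound 3 to compound 4 can be read. No evidence at hand bears on this result. The compounds shown leave open how compound 4 stands numerically against compound 1, its neighbour by one fluoro.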